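Trimethoxyphenyl amide on a dichlorophenyl dihydropyridine core

The compounds below may be only part of what the source reports. "The series", "measured", "known", "first", "only" and "open" are said of these compounds alone.

Measured compounds:
Compound 1 `N#CC1=C(N)N(c2ccc(S(N)(=O)=O)cc2)C2=C(C(=O)CCC2)C1c1ccc(Cl)cc1Cl` gives 40% in a functional assay on Ehrlich cells (Mus musculus) for cytotoxicity, read by trypan blue exclusion, with a stated time of 2 h, tested at 10 ug/mL; on this read-out lower numbers stand for a weaker effect and higher numbers for a stronger effect at the one concentration tested.
Compound 2 `N#CC1=C(NC(=O)C2CC2)N(c2ccc(S(N)(=O)=O)cc2)C2=C(C(=O)CCC2)C1c1ccc(Cl)cc1Cl` gives 20% in this assay.
Compound 3 `Cc1ccc(C(=O)NC2=C(C#N)C(c3ccc(Cl)cc3Cl)C3=C(CCCC3=O)N2c2ccc(S(N)(=O)=O)cc2)cc1` gives 20% in this assay.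

Compound 3 stands level with compound 2 at the digits reported, and the two together are the lowest of the three numbers; its furthest neighbour is compound 1, from which the step of a number 20 percentage points lower from compound 1 to compound 3 (beyond the scatter) runs. The step of a number 20 percentage points lower from compound 1 to compound 2 (beyond the scatter) is of the same size, so replacing the hydrogen on the amine nitrogen with either acyl group lowers the read-out in this assay by a modest, similar amount.

Compound 4 `COc1cc(C(=O)NC2=C(C#N)C(c3ccc(Cl)cc3Cl)C3=C(CCCC3=O)N2c2ccc(S(N)(=O)=O)cc2)cc(OC)c1OC` differs from compound 3 in one place: 3,4,5-trimethoxyphenyl in place of 4-methylphenyl on a carbonyl carbon. The measured step that bears most directly on this change is no change at the digits printed from compound 2 to compound 3 (within the scatter), where the group on the same carbonyl carbon was exchanged without any change beyond the scatter. Going by the values given here, nothing among the measured compounds speaks for the methoxy groups shifting the read-out in this assay, so the expectation is a step of no change at the digits printed from compound 3 to compound 4 (within the scatter), that is, none beyond the scatter. Compound 4 is therefore estimated at 20%, within a range from 10% to 35%.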

Compound 4, a percentage reported as activity, at one concentration (the size of the read-out at that concentration, not a potency): 0%
For compound 4 the middle estimate is 20 percentage points above the measured one, and the stated range ends above it.
By their numbers in this assay, from the lowest: compound 4; then compounds 2 and 3 (each within the scatter of the next); then compound 1.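

The group on this carbonyl carbon can change the result after all: exchanging cyclopropyl for 4-methylphenyl gave no change at the digits printed from compound 2 to compound 3 (within the scatter) in this assay, whereas 3,4,5-trimethoxyphenyl gives a number 20 percentage points lower from compound 3 to compound 4 (beyond the scatter) and a number 20 percentage points lower from compound 2 to compound 4 (beyond the scatter). The entering group has 12 heavy atoms against 7 in 4-methylphenyl and brings 3 hydrogen-bond acceptors against 0, but these differences arrive together in one exchange, so the compounds cannot show which of them goes with the lower number. Nothing available here accounts for the drop.

On these data alone, it remains open whether a smaller change on the same ring, such as a 4-methoxyphenyl group, would lower the number as far as the full 3,4,5-trimethoxyphenyl group does. As far as these compounds go, it is also open whether any group on this carbonyl carbon, for instance a longer alkyl chain or a phenyl ring bearing a carboxylic acid or an amine, could bring the read-out back towards the unacylated compound 1 at 40%.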